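Swapping an Imidazole Amide for a Hydroxyphenyl Amide

The source may report more compounds than this note shows. Statements on the series, on what has been measured and on what is new or still open speak of the compounds shown alone.

Measured so far in a toxicity assay on THP-1 cells (Homo sapiens) for inhibition; a higher number here means that more compound is tolerated, a lower number that less compound is tolerated:
- compound 1 `COc1ccc(-c2cnc(NC(=O)c3cnc[nH]3)n2C)cc1`: compound 1 gives > 100000 nM, a limit of the assay rather than a number.
- compound 2 `Cn1c(-c2ccc(Br)cc2)cnc1NC(=O)c1ccc(F)cc1`: compound 2 gives 46000 nM.
- compound 3 `O=C(Nc1ncc(-c2ccccc2)o1)c1ccc(Cl)cc1`: compound 3 gives 10000 nM.

Compound 1 stands at the limit of > 100000 nM in this assay, at which 1 of the 3 values shown sits, so its true tolerance is known only as beyond that limit, while compounds 2 and 3 each give a number. Compound 4 `COc1ccc(-c2cnc(NC(=O)c3cccc(O)c3)n2C)cc1` differs from compound 1 in one place: 3-hydroxyphenyl in place of 1H-imidazol-5-yl on a carbonyl carbon. Among the measured compounds shown here, with no pair of measured compounds sharing exactly this change, the step from compound 1 to compound 4 in this assay is expected to be small to moderate and downward, an at least 1.6-fold lower number from compound 1 to compound 4 (0.22 log units; that floor lies within the scatter), likely within or close to the scatter. Compound 4 is estimated at 60000 nM, between 15000 nM and 250000 nM.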

Compound 4, half-maximal cytotoxic concentration: > 100000 nM
Compound 4 ended at the assay's limit (the forecaster's own chance of this, stated with the estimate: 40%); at least 1.6-fold (0.22 log units) between middle value and limit.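

Compound 1 and compound 4 both end at a limit rather than a number, so the step between them in this assay cannot be read: the limit of > 100000 nM in this assay, at which 2 of the 4 values shown sit. Going by these compounds, how far either compound's true tolerance lies beyond that limit stays open.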